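Thioamide Tail Change on a Pyridazinone Core in a Gastric Assay

The source may report more compounds than this note shows. Statements on the series, on what has been measured and on what is new or still open speak of the compounds shown alone.

Of the compounds shown here, two that share a core have been measured in a functional assay on the whole organism (stomach) for inhibition, with Rattus norvegicus as the target, at a dose of 100 mg/kg by the intraduodenal route; on this read-out lower numbers stand for less inhibition and higher numbers for more inhibition at the one dose given (going by the name of the read-out). Compound 1 `N=C(S)CCn1nc(-c2cccs2)ccc1=O` gives 50.2%, and compound 2 `CC/N=C(\S)CCn1nc(-c2ccccc2)ccc1=O` gives 50.3%. The two numbers sit within the scatter of each other, so compound 2 stands level with compound 1 and no order between them can be drawn from this assay.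

Compound 3 `O=c1ccc(-c2ccccc2)nn1CCC(=S)N1CCCC1` differs from compound 2 in one place: a group of 7 heavy atoms (5 carbon, 1 nitrogen, 1 sulfur; one five-membered non-aromatic ring with 1 hetero atom) in place of a group of 5 heavy atoms (3 carbon, 1 nitrogen, 1 sulfur; no ring), on a saturated chain carbon, two bonds along the chain from an aromatic nitrogen. Among the measured compounds shown here, no measured pair yet tells how such a change moves this read-out, so the size of the step cannot be read from data. Since both compound 1 and compound 2 land at the same level in this assay, the step from compound 2 to compound 3 is expected to be small, a number 2.3 percentage points lower from compound 2 to compound 3 (within the scatter), and most likely within the scatter in either direction. Compound 3 is therefore estimated to give about 48% in this assay, with a range from 25% to 70%.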

Compound 3, a percentage reported as inhibition, in the whole organism at one dose (the size of the read-out at that dose, not a potency): 38.2%
Compound 3: the middle estimate sits 9.8 percentage points above what was measured; the measured number falls inside the stated range.
By their numbers in this assay, from the lowest: compound 3; then compounds 1 and 2 (each within the scatter of the next).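

Among the compounds shown here, compound 1 and compound 2 gave no step at this position; compound 3 supplies the first. In this assay, the change on a saturated chain carbon, two bonds along the chain from an aromatic nitrogen, gives a number 12.1 percentage points lower from compound 2 to compound 3 (beyond the scatter) and shows that this read-out can respond to the group placed there. The entering group has one five-membered non-aromatic ring with 1 hetero atom and 0 hydrogen-bond donors, whereas the leaving group has no ring and 1 hydrogen-bond donor, but nothing measured here explains the step.

This single step cannot separate the ring from the loss of the donor, and a diethylamino group or a morpholine ring at the same place would bear on that. As far as these compounds go, it also remains open whether the step would carry over to the core of compound 1.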